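The source may hold more compounds than are shown below. What is called first, only, known or untested is meant among the compounds shown, and "the series" means these compounds.

Compounds measured in an assay on a cell-free system (plasma) for inhibition of proteinase-activated receptor 1 (Homo sapiens), read by flow cytometry, with a stated time of 20 min; on this read-out lower numbers stand for stronger inhibition and higher numbers for weaker inhibition:

compound 1, `CCCC(=O)Nc1cccc(NC(=O)c2ccccc2Cl)c1`: 1100 nM
compound 2, `CCCC(=O)Nc1cccc(NC(=O)c2ccccc2C)c1`: 770 nM

Of these two, compound 2 shows the smaller number in this assay, but the step of a 1.4-fold lower number from compound 1 to compound 2 (0.15 log units; within the scatter) lies within the scatter, so the two compounds cannot be told apart on the numbers available.

Compound 3, `CCCC(=O)Nc1cccc(NC(=O)c2ccccc2CC)c1`, differs from compound 2 by methyl in place of hydrogen on a saturated chain carbon bound to an aromatic carbon. Among the measured compounds shown here, the only measured step that touches the same part of the shared core is a 1.4-fold lower number from compound 1 to compound 2 (0.15 log units; within the scatter), where one small aromatic substituent replaced another and the number did not move beyond the scatter. On that basis the step of a 1.1-fold lower number from compound 2 to compound 3 (0.04 log units; within the scatter) is expected to be small as well, with no clear direction. The number expected for compound 3 in this assay is therefore 700 nM, within a range from 250 nM to 2000 nM, and the measurement will show whether the lengthened group changes anything.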

Compound 3, half-maximal inhibitory concentration: 520 nM
Compound 3: middle estimate off by 1.3-fold (0.13 log units), on the high side, and the stated range covers the measured number.
By their numbers in this assay, from the lowest: compounds 3, 2 and 1 (each within the scatter of the next, the first and the last beyond it).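

In this assay, going from methyl to ethyl on this aromatic carbon reads as a 1.5-fold lower number from compound 2 to compound 3 (0.17 log units; within the scatter), so the added methyl on the saturated chain carbon leaves compound 3 indistinguishable from compound 2. Among the compounds shown here, the only step at this position that passes the scatter is a 2.1-fold lower number from compound 1 to compound 3 (0.33 log units; beyond the scatter), with ethyl in place of chloro, and it is a modest separation that compound 2 did not reach against compound 1. Nothing available accounts for these numbers.

The compounds shown leave open whether a longer chain such as propyl, or a branched one such as isopropyl, would move the number further. They also leave open what a methoxy group or an amine on this aromatic carbon would do, and whether a change elsewhere on the shared core would matter more.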